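Trimming the urea substituent to hydrogen: a cytotoxicity estimate

This account rests on a few compounds, and the source may have more. Where it says the series, first, only, none or still open, it means among the compounds named here.

Measured compounds in a functional assay on HEL cells (Homo sapiens) for cytotoxicity, read by microscopy; on this read-out lower numbers stand for higher toxicity in this test and higher numbers for lower toxicity in this test:
compound 1, `Cc1cn([C@@H]2O[C@H](CO[Si](C)(C)C(C)(C)C)[C@@]3(OS(=O)(=O)C=C3NCC(=O)C(=O)N3CCC3)[C@H]2O[Si](C)(C)C(C)(C)C)c(=O)n(C)c1=O`, compound 1 gives 65000 nM
compound 2, `CCOC(=O)NC(=O)NC1=CS(=O)(=O)O[C@@]12[C@@H](CO[Si](C)(C)C(C)(C)C)O[C@@H](n1cc(C)c(=O)n(C)c1=O)[C@@H]2O[Si](C)(C)C(C)(C)C`, compound 2 gives 16000 nM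
compound 3, `CCOC(=O)CNC(=O)NC1=CS(=O)(=O)O[C@@]12[C@@H](CO[Si](C)(C)C(C)(C)C)O[C@@H](n1cc(C)c(=O)n(C)c1=O)[C@@H]2O[Si](C)(C)C(C)(C)C`, compound 3 gives 16000 nM

Compound 3 shares the lowest number of the three with compound 2: the step of no change at the digits printed from compound 2 to compound 3 (within the scatter) lies within the scatter, while the step of a 4.1-fold lower number from compound 1 to compound 3 (0.61 log units; beyond the scatter) is a modest move beyond it, matched by a 4.1-fold lower number from compound 1 to compound 2 (0.61 log units; beyond the scatter).

Compound 4, `Cc1cn([C@@H]2O[C@H](CO[Si](C)(C)C(C)(C)C)[C@@]3(OS(=O)(=O)C=C3NC(N)=O)[C@H]2O[Si](C)(C)C(C)(C)C)c(=O)n(C)c1=O`, carries the change (hydrogen in place of (ethoxycarbonyl)methyl on an amide-type nitrogen). For the measured compounds named here, the only measured step that touches this amide-type nitrogen is no change at the digits printed from compound 2 to compound 3 (within the scatter), where swapping one ester-bearing group for another left the number unchanged. Going by the values given here, no measured pair shows the group removed entirely, so the expectation rests on that one quiet step and on the lack of any other evidence.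

Compound 4 is therefore expected to stay close to compound 3, with a step of no change at the digits printed from compound 3 to compound 4 (within the scatter) that is not expected to exceed the scatter. The estimate for compound 4 in this assay is 16000 nM, with a range from 6000 nM to 50000 nM.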

Compound 4, minimum cytotoxic concentration: 16000 nM
Estimate against measurement, compound 4: no gap at the digits printed, and the stated range covers the measured number.
By their numbers in this assay, from the lowest: compounds 2, 3 and 4 (each within the scatter of the next); then compound 1.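

The step of no change at the digits printed from compound 3 to compound 4 (within the scatter) in this assay removes the whole (ethoxycarbonyl)methyl from the amide-type nitrogen, and the step of no change at the digits printed from compound 2 to compound 4 (within the scatter) does the same for ethoxycarbonyl, so this nitrogen now holds its number with no ester-bearing group at all, where before one such group had only been swapped for another. The step of a 4.1-fold lower number from compound 1 to compound 4 (0.61 log units; beyond the scatter) shows that the plain carbamoyl on the amine nitrogen, in place of (((azetidin-1-yl)carbonyl)carbonyl)methyl, matches the two larger ureas in their distance from compound 1. Nothing available explains why the number stays level across these three ureas.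

As far as these compounds go, it remains open whether a carboxylic acid, an amine or a longer alkyl chain on the amide-type nitrogen would leave the number in place. From the compounds shown here alone, it is also open whether an acetyl group on the amine nitrogen would do the same as carbamoyl.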